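The source may hold more compounds than are shown below. What is called first, only, known or untested is meant among the compounds shown, and "the series" means these compounds.

Measured so far:
Compound 1 `COc1ccc(CNCc2c(OC)cc(Oc3cccc(Nc4ccccc4)c3)cc2OC)cc1` gives 1910 nM in a functional assay on DLD-1 cells (Homo sapiens) for inhibition, read by MTT assay, with a stated time of 72 h; a lower number here means a stronger inhibitor, a higher number a weaker inhibitor.
Compound 2 `COc1cc(Oc2cccc(Nc3ccccc3)c2)cc(OC)c1CNCc1ccc(F)cc1` gives 2650 nM in this assay.

For the measured compounds named here, compound 2 shows the higher of the two numbers, its only neighbour being compound 1, but the step of a 1.4-fold higher number from compound 1 to compound 2 (0.14 log units; within the scatter) lies within the scatter, so the two compounds stand level in this assay. Compound 3 `CNCc1c(OC)cc(Oc2cccc(Nc3ccccc3)c2)cc1OC` differs from compound 2 by hydrogen in place of 4-fluorophenyl on a saturated chain carbon bound to an amine nitrogen. Going by the values given here, no measured step speaks directly to this change. Among the compounds with values here, the single step in hand, a 1.4-fold higher number from compound 1 to compound 2 (0.14 log units; within the scatter), exchanges one substituent on the very ring that is now removed and moves the number little, which says nothing about what losing the ring itself does. The expectation for compound 3 therefore rests only on the size of the removed group: compound 3 is expected to give a higher number in this assay, with a step of a 3.0-fold higher number from compound 2 to compound 3 (0.48 log units; beyond the scatter) from compound 2. The estimate for compound 3 is 8000 nM, within a range from 2500 nM to 25000 nM.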

Compound 3, half-maximal inhibitory concentration: 11900 nM
Estimate against measurement, compound 3: 1.5-fold (0.17 log units) below; low and high end bracket the measured number.
By their numbers in this assay, from the lowest: compounds 1 and 2 (each within the scatter of the next); then compound 3.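

In this assay, the earlier step changed only a substituent on this ring and stayed within the scatter, whereas removing the whole ring moves the number beyond it. Hydrogen in place of 4-fluorophenyl gives a 4.5-fold higher number from compound 2 to compound 3 (0.65 log units; beyond the scatter) in this series, and hydrogen in place of 4-methoxyphenyl gives a 6.2-fold higher number from compound 1 to compound 3 (0.79 log units; beyond the scatter) at the same saturated chain carbon bound to an amine nitrogen, so both modest steps run the same way. No measured property is at hand to explain this.

The compounds shown set only two substituted phenyl rings against hydrogen, so it remains open whether an aromatic ring is what matters here. A cyclohexyl group, a pyridine ring or a longer alkyl chain at this carbon would separate the aromatic ring from the mere presence of further carbon atoms.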